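The source may hold more compounds than are shown below. What is called first, only, known or untested is meant among the compounds shown, and "the series" means these compounds.

Working notes on the series

Compound 1 `CN(C)c1ccc2c(=O)c(C(=O)Nc3cc(F)cc(F)c3)cn(-c3ccc(OCCCCCCC[N+]45CCN(CC4)CC5)cc3F)c2n1` carries one tail on the chain and, in an assay on LX2 cells for inhibition of COL1A1 promoter (Homo sapiens), read by a luciferase reporter, with a stated time of 24 h, tested at 20 uM (a higher number here means a stronger effect of the compound at the concentration tested, a lower number a weaker effect), compound 1 gives 9.02%. Compound 2 `CN(C)c1ccc2c(=O)c(C(=O)Nc3cc(F)cc(F)c3)cn(-c3ccc(OCCCCCCC[n+]4ccccc4)cc3F)c2n1` differs only in the tail, and in this assay compound 2 gives 15.4%; the step of a number 6.4 percentage points higher from compound 1 to compound 2 (within the scatter) therefore says nothing beyond the scatter. Compound 3 `CC[N+]1(CCCCCCCOc2ccc(-n3cc(C(=O)Nc4cc(F)cc(F)c4)c(=O)c4ccc(N(C)C)nc43)c(C)c2)CCCCC1` stands apart: in this assay compound 3 is reported as "not active" (no number reported), so no number places it against compounds 1 and 2, only that it falls outside what is reported as an effect. Compound 4 `CC[N+]1(CCCCCCCOc2ccc(-n3cc(C(=O)Nc4cc(F)cc(F)c4)c(=O)c4ccc(N(C)C)nc43)c(F)c2)CCCCC1` is the next step, and its change is fluoro in place of methyl on an aromatic carbon. Within the data shown here, no measured step bears on this change: the only step in hand, from compound 1 to compound 2, concerns the tail and was within the scatter, and compound 1 already carries fluoro at the place where compound 4 gains it. Starting from an inactive compound 3, a small read-out is expected, at most near the weak values of compounds 1 and 2. The value expected for compound 4 in this assay is 7%, with a range from 0% to 20%.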

Compound 4, a percentage reported as inhibition, at one concentration (the size of the read-out at that concentration, not a potency): "not active" (no number reported)
The entry for compound 4 holds no number, so the estimate cannot be set against anything.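

In this assay compound 3 and compound 4 are both reported as "not active", so no step can be read for fluoro in place of methyl, and nothing measured bears on this result. As far as these compounds go, whether that change alters the read-out on a compound with a measurable effect stays open.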